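Chloro in Place of Trifluoromethyl: Forecast for Compound 4

The compounds below may be only part of what the source reports. "The series", "measured", "known", "first", "only" and "open" are said of these compounds alone.

Compound 3 `O=C1COc2ccc(NC(=O)C3CCN(c4ccccc4C(F)(F)F)CC3)cc2N1` was tested in an assay on HEK293 cells for displacement of a labelled ligand from transient receptor potential cation channel subfamily V member 1 (Homo sapiens) (on this read-out higher numbers stand for weaker inhibition and lower numbers for stronger inhibition), where compound 3 gives 68 nM. Going by the values given here, that leaves compound 3 second highest of the three numbers known, and all three sit within the scatter of one another. Compound 1 `Cc1ccccc1N1CCC(C(=O)Nc2ccc3c(c2)NC(=O)CO3)CC1` gives 61 nM in this assay, and a 1.1-fold higher number from compound 1 to compound 3 (0.05 log units; within the scatter). Compound 2 `O=C1COc2ccc(NC(=O)C3CCN(c4cccc(Cl)c4)CC3)cc2N1` gives 97 nM in this assay, and a 1.4-fold lower number from compound 2 to compound 3 (0.15 log units; within the scatter).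

Compound 4 `O=C1COc2ccc(NC(=O)C3CCN(c4ccccc4Cl)CC3)cc2N1` differs from compound 3 in one place: chloro in place of trifluoromethyl on an aromatic carbon. Among the compounds with values here, no measured pair shows chloro against trifluoromethyl on that aromatic carbon, so the bearing of the known steps is indirect. The two steps that touch the same aryl group, the methyl-to-trifluoromethyl change behind a 1.1-fold higher number from compound 1 to compound 3 (0.05 log units; within the scatter) and the aryl swap behind a 1.4-fold lower number from compound 2 to compound 3 (0.15 log units; within the scatter), both stayed inside the scatter. On that basis the expected step is small, a 1.0-fold higher number from compound 3 to compound 4 (0.01 log units; within the scatter), with no clear direction. Compound 4 is expected to give 70 nM in this assay, with a likely range from 30 nM to 170 nM.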

Compound 4, inhibition constant: 93 nM
The estimate for compound 4 lay 1.3-fold (0.12 log units) below the measured number; the measured number falls inside the stated range.
By their numbers in this assay, from the lowest: compounds 1, 3, 4 and 2 (each within the scatter of the next).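

On this aromatic carbon, ortho to a large group, this assay gives a step for chloro in place of trifluoromethyl (a 1.4-fold higher number from compound 3 to compound 4 (0.14 log units; within the scatter)) and one for chloro in place of methyl (a 1.5-fold higher number from compound 1 to compound 4 (0.18 log units; within the scatter)), so the read-out does not separate chloro, methyl and trifluoromethyl here. The first comparison of one substituent at two places on the aryl group, 2-chlorophenyl in place of 3-chlorophenyl (a 1.0-fold lower number from compound 2 to compound 4 (0.02 log units; within the scatter)), also stays within the scatter, so among these compounds neither the identity of the group nor this shift of chloro produces a step beyond it. Nothing available explains why these steps are so small.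

The compounds shown leave open whether a methoxy group, a nitrile or an amine on this carbon would stay within the same scatter. They also leave open what an unsubstituted phenyl group would give on the same core.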